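Changing the side chain of a GPR39 agonist

The compounds below may be only part of what the source reports. "The series", "measured", "known", "first", "only" and "open" are said of these compounds alone.

Compound 1 `CCCCCCCCOC1CC(=O)Nc2c1c(C)nn2-c1ncnc2nc[nH]c12`: 8 nM
Compound 2 `C=CCN1c2c(n(C)c(=O)n(C)c2=O)NC1N/N=C/c1ccc(O)cc1O`: 340 nM

In a functional assay on HEK293 cells for agonist activity at G-protein coupled receptor 39 (Homo sapiens), read by scintillation proximity assay and inositol phosphate accumulation, with a stated time of 75 min, in the presence of a further agent that is not named here (on this read-out higher numbers stand for an effect only at larger amounts of compound and lower numbers for an effect already at smaller amounts), compound 1 gives the lower of the two numbers, and its gap to compound 2 lies beyond the scatter. Compound 3 `Cc1nn(-c2ncnc3nc[nH]c23)c2c1C(C(=O)N(C)c1ccccc1)CC(=O)N2` differs from compound 1 in one place: methyl(phenyl)carbamoyl in place of octyloxy on a saturated ring carbon. No such exchange between measured compounds is at hand, so the effect must be guessed. Compound 1 sets a low starting point; the step of a 5.0-fold higher number from compound 1 to compound 3 (0.70 log units; beyond the scatter) is expected to be a moderate loss. Compound 3 is estimated to give 40 nM in this assay, within 8 nM to 300 nM.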

Compound 3, half-maximal effective concentration: 32 nM
Compound 3: middle estimate off by 1.3-fold (0.10 log units), on the high side; measured number inside the range.
By their numbers in this assay, from the lowest: compound 1; then compound 3; then compound 2.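

In this assay, methyl(phenyl)carbamoyl in place of octyloxy on the saturated ring carbon gives a 4.0-fold higher number from compound 1 to compound 3 (0.60 log units; beyond the scatter) and so costs only a modest step. This position therefore accepts a group with a six-membered aromatic ring as well as a chain with no ring. Nothing at hand explains this step. As far as these compounds go, whether a shorter alkoxy chain, a hydroxyl or a simple amine on this carbon would give a lower or higher number remains open. So does the contribution of the methyl on the amide nitrogen.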